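Removing a methyl from the chain of a hydantoin

The compounds below may be only part of what the source reports. "The series", "measured", "known", "first", "only" and "open" are said of these compounds alone.

Measured compounds:
compound 1 `CCC(C)C1NC(=O)N(C2CCCCC2)C1=O` gives > 50 ug/mL in a functional assay on HEL cells (Homo sapiens) for cytotoxicity; a higher number here means that more compound is tolerated, a lower number that less compound is tolerated
compound 2 `CCC(C)C(NC(=O)n1nnc2ccccc21)C(=O)NCc1ccccc1` gives 156 ug/mL in this assay

Compound 1 stands at a limit of the method in this assay: its value of > 50 ug/mL is not a number but the boundary of what was measured, which is the limit of > 50 ug/mL in this assay, at which 1 of the 2 values shown sits. Among the measured compounds shown here, compound 2 gives a number in this assay, 156 ug/mL, and as compound 1 and compound 2 differ in more than one place, the two values show only that both compounds are tolerated to a considerable degree.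

The unmeasured compound 3 `CC(C)C1NC(=O)N(C2CCCCC2)C1=O` keeps the whole core of compound 1 and alters only the chain: hydrogen in place of methyl on a saturated chain carbon, two bonds along the chain from a saturated ring carbon, that is sec-butyl becomes isopropyl. For the measured compounds named here, with no measured step between compounds of this kind, the expected change in this assay is none beyond the scatter, in either direction. Compound 3 is therefore expected to give about 60 ug/mL, within 30 ug/mL to 150 ug/mL, the step from compound 1 to compound 3 being estimated at a step that the limit leaves unreadable from compound 1 to compound 3, and most likely the outcome is again reported as a limit rather than a number.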

Compound 3, half-maximal cytotoxic concentration: > 50 ug/mL
Compound 3: a limit, no number (the forecaster's own chance of this, stated with the estimate: 70%); the middle value lies beyond the limit too.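

In this assay compound 3 gives > 50 ug/mL as a limit and not a number. Compound 1 likewise stands at a limit, so no step can be read between compound 1 and compound 3. The compounds shown leave open what number either compound would give, and so whether going from sec-butyl to isopropyl changes the tolerated concentration at all.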